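This account rests on a few compounds, and the source may have more. Where it says the series, first, only, none or still open, it means among the compounds named here.

Measured so far in a functional assay on PC-3 cells (Homo sapiens) for inhibition, read by MTT assay, with a stated time of 48 h; on this read-out higher numbers stand for weaker inhibition and lower numbers for stronger inhibition
- compound 1 (`COc1ccc(-n2c(SCC(=O)Nc3ccc(Cl)cc3)nnc2-c2cc(OC)c(OC)c(OC)c2)cc1`) gives 6290 nM
- compound 2 (`COc1cc(-c2nnc(SCC(=O)c3ccc4ccccc4c3)n2-c2ccc(N(C)C)cc2)cc(OC)c1OC`) gives 18100 nM

Of these two, compound 2 has the higher number and so the weaker inhibition in this assay. Its gap to compound 1 lies beyond the usual scatter of repeated measurements.

Compound 3 (`COc1cc(-c2nnc(SCC(=O)Nc3ccc(Cl)cc3)n2-c2ccc(N(C)C)cc2)cc(OC)c1OC`) has not yet been measured. Its difference from compound 2 is (4-chlorophenyl)amino in place of naphthalen-2-yl on a carbonyl carbon and amounts to (4-chlorophenyl)amino in place of naphthalen-2-yl on a carbonyl carbon.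

Among the compounds with values here, no step between measured compounds isolates this change, so the evidence is thin. Compound 1 at 6290 nM also carries (4-chlorophenyl)amino on a carbonyl carbon, which points towards a lower number. The core of compound 1 is not the same as that of compound 3, however, so only a moderate shift towards stronger inhibition is expected, and it may not clear the scatter by much. The estimated move is a 2.3-fold lower number from compound 2 to compound 3 (0.35 log units; beyond the scatter) in this assay and remains an expectation only. For compound 3 the expected value is 8000 nM with an estimated range from 3000 nM to 20000 nM in this read-out.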

Compound 3, half-maximal inhibitory concentration: > 60000 nM
Compound 3 gave a limit, no number (the forecaster's own chance of this, stated with the estimate: 3%); middle value at least 7.5-fold (0.87 log units) away from the limit.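

Replacing naphthalen-2-yl with (4-chlorophenyl)amino on a carbonyl carbon gives an at least 3.3-fold higher number from compound 2 to compound 3 (0.52 log units; beyond the scatter) in this assay, so with dimethylamino on the aromatic carbon, this position does not tolerate the change without a clear loss of inhibition. Compound 3 gives a limit of the assay and not a number: the limit of > 60000 nM in this assay, at which 1 of the 3 values shown sits. With (4-chlorophenyl)amino held in place, dimethylamino in place of methoxy on an aromatic carbon gives an at least 9.5-fold higher number from compound 1 to compound 3 (0.97 log units; beyond the scatter), so (4-chlorophenyl)amino on the carbonyl carbon does not carry inhibition on its own, and its effect in this pair depends on the group at the other site.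

Both steps end at the limit, so their true sizes remain unknown, and the compounds shown cannot tell whether the two changes act independently or reinforce each other. Also open, on these data alone, is how the carbonyl position would read with a small amine such as methylamino or with a saturated ring such as piperidin-1-yl, which would show whether the aromatic ring of the (4-chlorophenyl)amino group matters at this position.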